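Extending a methoxy substituent into a methyl ester chain

A few compounds are considered here, and "the series" means these few. Any claim that something is new, unique, unknown or untested is made for them only; others in the source may bear on it.

Measured compounds:
- compound 1, `CCCc1ccc(-c2ccc(N(C[C@@H](N)[C@@H](C)CC)C(=O)[C@@H]3C[C@H]3c3ccccc3)cc2)cc1`: 61 nM
- compound 2, `CC[C@H](C)[C@H](N)CN(C(=O)[C@@H]1C[C@H]1c1ccccc1)c1ccc(-c2ccc(OC(C)C)cc2)cc1`: 72 nM
- compound 3, `CC[C@H](C)[C@H](N)CN(C(=O)[C@@H]1C[C@H]1c1ccccc1)c1ccc(-c2ccc(OC)cc2)cc1`: 120 nM

All three numbers come from a functional assay for agonist activity at G protein-coupled receptor 88 (Homo sapiens), read by HTRF and cAMP accumulation; on this read-out lower numbers stand for an effect already at smaller amounts and higher numbers for an effect only at larger amounts of compound. Compound 3 sits at the upper end of the three, yet the two steps leading to it, a 2.0-fold higher number from compound 1 to compound 3 (0.29 log units; within the scatter) and a 1.7-fold higher number from compound 2 to compound 3 (0.22 log units; within the scatter), are both within the scatter, so the three compounds cannot be told apart with confidence.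

Compound 4, `CC[C@H](C)[C@H](N)CN(C(=O)[C@@H]1C[C@H]1c1ccccc1)c1ccc(-c2ccc(CCC(=O)OC)cc2)cc1`, is not yet measured. It differs from compound 3 only in one place: 2-(methoxycarbonyl)ethyl in place of methoxy on an aromatic carbon. The bearing steps are those in which this same position carried a larger group, propyl in compound 1 and isopropoxy in compound 2, and both of these gave numbers within the scatter of compound 3. A further enlargement to the 2-(methoxycarbonyl)ethyl chain is therefore expected to leave the number within the scatter, possibly a little lower, giving an expected step of a 1.4-fold lower number from compound 3 to compound 4 (0.15 log units; within the scatter).

For compound 4 the estimate in this assay is 85 nM, within a range from 30 nM to 250 nM.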

Compound 4, half-maximal effective concentration: 110 nM
The estimate for compound 4 lay 1.3-fold (0.11 log units) below the measured number; measured number inside the range.
By their numbers in this assay, from the lowest: compounds 1, 2, 4 and 3 (each within the scatter of the next).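

Until now this aromatic carbon, para to a large group, had held only propyl, isopropoxy and methoxy, and compound 4 shows that in this assay it can also carry the 2-(methoxycarbonyl)ethyl chain, which brings a carbonyl and a second oxygen: the swap from methoxy gives a 1.1-fold lower number from compound 3 to compound 4 (0.04 log units; within the scatter) and so cannot be told apart from no change. The same holds against the ether of the isopropoxy compound, with a 1.5-fold higher number from compound 2 to compound 4 (0.18 log units; within the scatter) as the printed step. Ending the chain in methoxycarbonyl rather than methyl gives a 1.8-fold higher number from compound 1 to compound 4 (0.26 log units; within the scatter), so this ester end leaves the number within the scatter of the plain propyl chain.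

As far as these compounds go, whether a carboxylic acid or an amine at the end of this chain, or a longer chain, would also stay within the scatter remains open. Nothing available here explains why these different groups give such similar numbers.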